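Replacing the (Carboxymethyl)amino Group: Notes Toward Compound 4

This account rests on a few compounds, and the source may have more. Where it says the series, first, only, none or still open, it means among the compounds named here.

Measured so far:
- compound 1, `O=C1NCc2c(NCc3ccccc3[N+](=O)[O-])cccc21`: 9%
- compound 2, `O=[N+]([O-])c1cccc(CNc2cc(C(F)(F)F)cc3[nH]ncc23)c1`: 69%
- compound 3, `O=C(O)CNc1cccc(CNc2cc(C(F)(F)F)cc3[nH]ncc23)c1`: 8%

In an assay for inhibition of Indoleamine 2,3-dioxygenase 1 (Homo sapiens), with stated times of 10 min and 60 min, tested at 100 uM (a lower number here means a weaker effect, a higher number a stronger effect of the compound at the concentration tested), compound 3 gives the lowest of the three numbers. Compound 1 sits within the scatter of it, with 9%, so no order between compound 1 and compound 3 can be read. Compound 2 gives 69%, a number far higher than either of the other two.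

Compound 4, `FC(F)(F)c1cccc(CNc2cc(C(F)(F)F)cc3[nH]ncc23)c1`, is not yet measured. It differs from compound 3 in one place: trifluoromethyl in place of (carboxymethyl)amino on an aromatic carbon.

Within the data shown here, only one measured step touches this position: a number 61 percentage points lower from compound 2 to compound 3 (beyond the scatter). That step shows that the (carboxymethyl)amino group, on the same aromatic carbon, goes with a strongly reduced read-out relative to a nitro group there. Compound 4 removes the (carboxymethyl)amino group again and puts in a trifluoromethyl, a group that carries no hydrogen-bond donors or acceptors, as a nitro group does not carry donors either. Nothing measured tells how trifluoromethyl itself behaves here, so a full return to the level of compound 2 cannot be assumed.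

The step is therefore expected to be a rise in this assay, estimated as a number 32 percentage points higher from compound 3 to compound 4 (beyond the scatter), beyond the scatter but uncertain in size. For compound 4 the expected value in this assay is 40%, in the range 12% to 68%.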

Compound 4, a percentage reported as inhibition, at one concentration (the size of the read-out at that concentration, not a potency): 49%
Compound 4: the middle estimate sits 9 percentage points below what was measured; the measured number falls inside the stated range.
By their numbers in this assay, from the lowest: compounds 3 and 1 (each within the scatter of the next); then compound 4; then compound 2.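

In this assay, the loss seen with (carboxymethyl)amino on this aromatic carbon does not depend on nitro being the comparison group: a number 41 percentage points higher from compound 3 to compound 4 (beyond the scatter). Trifluoromethyl and nitro are still not interchangeable here, as the data show a number 20 percentage points lower from compound 2 to compound 4 (beyond the scatter), a modest step but one beyond the scatter. Of the three groups compared on this carbon, only (carboxymethyl)amino goes with a low number, so the position responds strongly to the group placed on it, and a good part of the read-out survives a change away from nitro.

Compound 1 differs from the others in more than one place, so its steps cannot be read, and no measurement at hand explains the differences among these three groups. Going by these compounds, it remains open where a nitrile, a plain amine or a carboxylic acid on the same carbon would fall, and whether the loss with (carboxymethyl)amino goes with its carboxylic acid, its amine nitrogen or the whole chain.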